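Amino ester series: cytotoxicity and an untested analogue

This account rests on a few compounds, and the source may have more. Where it says the series, first, only, none or still open, it means among the compounds named here.

Compound 1 `CC1(C)[C@H]2CC[C@]1(C)[C@H](OC(=O)CN1CCCCC1)C2` was tested in an ADME assay on HEK-293T cells (Homo sapiens) for cytotoxicity, read by MTT assay, with a stated time of 48 h (a lower number here means that less compound is tolerated, a higher number that more compound is tolerated), and gives 141000 nM. Compound 2 `CCN1CCN(CCC(=O)O[C@@H]2C[C@@H]3CC[C@@]2(C)C3(C)C)CC1` gives 264000 nM in this assay, and compound 3 `CCN1CCN(CCCC(=O)O[C@@H]2C[C@@H]3CC[C@@]2(C)C3(C)C)CC1` gives 131000 nM. Compound 1 thus sits between the other two numbers, and both gaps lie within the scatter, so the three measured compounds are not separated by this assay. Compound 4 `CN(C)CCC(=O)O[C@@H]1C[C@@H]2CC[C@@]1(C)C2(C)C` has not been tested. It differs from compound 1 as follows: (dimethylamino)methyl in place of piperidin-1-yl on a saturated chain carbon bound to a carbonyl carbon. The three measured compounds show no step beyond the scatter among their amine-bearing chains, so in this assay the expected step of a 1.1-fold higher number from compound 1 to compound 4 (0.03 log units; within the scatter) is one not beyond the scatter, in either direction. Compound 4 is estimated at 150000 nM in this assay, between 70000 nM and 320000 nM.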

Compound 4, half-maximal cytotoxic concentration: 505000 nM
Beside the measured number, compound 4's estimate is 3.4-fold (0.53 log units) below it, and the stated range ends below it.
By their numbers in this assay, from the lowest: compounds 3, 1, 2 and 4 (each within the scatter of the next, the first and the last beyond it).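

In this assay, within the data shown here, (dimethylamino)methyl in place of piperidin-1-yl on a saturated chain carbon bound to a carbonyl carbon gives a 3.6-fold higher number from compound 1 to compound 4 (0.55 log units; beyond the scatter) and is the first step beyond the scatter. Among these compounds, the number at this position therefore responds to a change of the amine-bearing group, which the earlier compounds did not show. No evidence at hand bears on the reason for this step.

The change removes the ring and alters the chain together, and the compounds shown do not tell which part carries the step. Piperidin-1-ylmethyl or a plain dimethylamino group at this place would separate the two.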